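The source may hold more compounds than are shown below. What is called first, only, known or untested is meant among the compounds shown, and "the series" means these compounds.

Measured in an in vitro ADME assay on microsomes from liver (Homo sapiens) for metabolic stability; on this read-out lower numbers stand for slow clearance and higher numbers for fast clearance:
compound 1 `CC(C)NC(=O)[C@H]1CC[C@@H](n2/c(=N/C(=O)c3cc(F)cc(Cl)c3)[nH]c3ccc(CN4CCC(C(C)(C)O)CC4)cc32)CC1`: 83 mL.min-1.g-1
compound 2 `CC(C)NC(=O)[C@H]1CC[C@@H](n2/c(=N/C(=O)c3cc(F)cc(C#N)c3)[nH]c3ccc(CN4CCC(C(C)(C)O)CC4)cc32)CC1`: 90 mL.min-1.g-1

For the measured compounds named here, compound 2, at 90 mL.min-1.g-1, cannot be separated from the only other measured compound. Compound 3 `CC(C)NC(=O)[C@H]1CC[C@@H](n2/c(=N/C(=O)c3ccccc3)[nH]c3ccc(CN4CCC(C(C)(C)O)CC4)cc32)CC1` carries phenyl in place of 3-cyano-5-fluorophenyl on a carbonyl carbon. Going by the values given here, the one measured step bearing on this is a 1.1-fold higher number from compound 1 to compound 2 (0.04 log units; within the scatter), cyano in place of chloro on an aromatic carbon, and it stays within the scatter. Among the compounds with values here, no measured compound has the plain phenyl, so the evidence is thin. In this assay no change beyond the scatter is expected, and the expected step is a 1.1-fold lower number from compound 2 to compound 3 (0.05 log units; within the scatter). The estimate for compound 3 is 80 mL.min-1.g-1, with an expected range of 45 mL.min-1.g-1 to 130 mL.min-1.g-1.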

Compound 3, intrinsic clearance in microsomes: 40 mL.min-1.g-1
Compound 3: middle estimate off by 2.0-fold (0.30 log units), on the high side; the whole stated range lies above it.
By their numbers in this assay, from the lowest: compound 3; then compounds 1 and 2 (each within the scatter of the next).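

In this assay, the plain phenyl gives a 2.3-fold lower number from compound 2 to compound 3 (0.35 log units; beyond the scatter) and a 2.1-fold lower number from compound 1 to compound 3 (0.32 log units; beyond the scatter). Change at this position on the carbonyl carbon can therefore move the read-out beyond the scatter, whereas exchanging chloro for cyano did not. No measurement at hand accounts for this difference.

Going by these compounds, whether both substituents must go for the step to appear remains open; a phenyl carrying fluoro alone would test this. Also open, on these data alone, is whether a methoxy group or a pyridine ring at this place keeps the lower clearance number.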